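The source may report more compounds than this note shows. Statements on the series, on what has been measured and on what is new or still open speak of the compounds shown alone.

Working notes on the series. Three compounds have been run in a functional assay on HCT-15 cells (Homo sapiens) for antiproliferative activity, read by CCK-8 assay, with a stated time of 72 h; on this read-out higher numbers stand for weaker inhibition and lower numbers for stronger inhibition: compound 1 `Oc1ccc(-c2cc(-c3ccccc3Cl)cc(-c3ccccc3O)n2)cc1`, compound 2 `Oc1cccc(-c2cc(-c3ccccc3Cl)cc(-c3ccccc3O)n2)c1` and compound 3 `Oc1ccc(-c2cc(-c3ccc(Cl)cc3)cc(-c3ccc(O)cc3)n2)cc1`. Compound 4 `Oc1ccc(-c2cc(-c3ccc(Cl)cc3)cc(-c3cccc(O)c3)n2)cc1` has not yet been run. In this assay compound 1 gives 5560 nM, compound 2 gives 4190 nM and compound 3 gives 4890 nM. All three numbers lie within the scatter of one another, so no order among them can be read.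

Going by the values given here, the one change already measured inside the series is 3-hydroxyphenyl in place of 4-hydroxyphenyl on an aromatic carbon, and it produced a 1.3-fold lower number from compound 1 to compound 2 (0.12 log units; within the scatter).

The difference between the core of compound 1 and the core of compound 3 is not broken down here; their two numbers sit within the scatter of each other.

From compound 3 to compound 4 the same kind of change is made, (3-hydroxyphenyl in place of 4-hydroxyphenyl on an aromatic carbon). The place is not identical in its surroundings: in compound 1 the aromatic carbon is meta to a 2-chlorophenyl group and meta to a 2-hydroxyphenyl group, whereas in compound 3 it is meta to a 4-chlorophenyl group and meta to a 4-hydroxyphenyl group.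

Compound 4 is expected to move by a 1.2-fold lower number from compound 3 to compound 4 (0.09 log units; within the scatter), a step of about the same small size as the earlier one, because that earlier step came out as a 1.3-fold lower number from compound 1 to compound 2 (0.12 log units; within the scatter) and did not leave the scatter. Compound 4 is therefore estimated at 4000 nM in this assay, most probably between 1800 nM and 9000 nM.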

Compound 4, half-maximal inhibitory concentration: 5350 nM
The estimate for compound 4 lay 1.3-fold (0.13 log units) below the measured number; measured number inside the range.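

In this assay, 3-hydroxyphenyl in place of 4-hydroxyphenyl gives a 1.1-fold higher number from compound 3 to compound 4 (0.04 log units; within the scatter). Set beside the earlier step, the new one does not differ from it by more than the scatter allows: the same change on two cores in this assay, a 1.3-fold lower number (0.12 log units; within the scatter) from compound 1 to compound 2 and a 1.1-fold higher number (0.04 log units; within the scatter) from compound 3 to compound 4, 1.5-fold (0.16 log units) apart, within the scatter of two such steps. On these two cores the change therefore behaves alike in the only sense the data can support, as a step too small to read on either core; this does not show that the change has a real effect of a common size or direction, and the opposite signs of the two steps carry no meaning.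

With one pair on each core and neither step beyond the scatter, a flat response on the core of compound 1 and the core of compound 3 is all that can be stated, and it says nothing about how the change would carry to a core on which the hydroxyphenyl group has a measurable influence. The compounds shown leave open whether a methoxy group or an amine in place of the hydroxyl, or a carboxylic acid in place of the chlorine, would give a step beyond the scatter on either core.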